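Methyl-to-Fluoro Exchange and Cytotoxicity

The source may report more compounds than this note shows. Statements on the series, on what has been measured and on what is new or still open speak of the compounds shown alone.

Measured so far in an ADME assay on MCF-10A cells (Homo sapiens) for cytotoxicity, read by MTT assay, with a stated time of 48 h; a lower number here means a stronger inhibitor, a higher number a weaker inhibitor:
Compound 1 `Cc1ccc(-c2nnc(COc3ccc(C#N)c(F)c3)o2)cc1` gives a value that is a limit of the assay, > 100000 nM.
Compound 2 `N#Cc1ccc(OCc2nnc(-c3ccc(F)cc3)o2)cc1F` gives 84200 nM.
Compound 3 `Cc1ccc(-c2nnc(COc3ccc(-c4nnco4)cc3)o2)cc1` gives a value that is a limit of the assay, > 100000 nM.

Compound 1 and compound 2 share a core and differ in one place, (fluoro in place of methyl on an aromatic carbon). The step this made in this assay was an at least 1.1-fold lower number from compound 1 to compound 2 (0.07 log units; that floor lies within the scatter), so the two values cannot be told apart with confidence. Compound 3 carries a different core; the difference between the core of compound 1 and the core of compound 3 is not broken down here. Compound 4 `Fc1ccc(-c2nnc(COc3ccc(-c4nnco4)cc3)o2)cc1` has not yet been measured in this assay; it stands to compound 3 as compound 2 stands to compound 1, (fluoro in place of methyl on an aromatic carbon), and the place of the change reads the same in both pairs, so this is the same change made a second time.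

Among the compounds with values here, two of the three values sit at the limit, as recorded in the limit of > 100000 nM in this assay, at which 2 of the 3 values shown sit, and the one pair that was measured on both sides showed no step beyond the scatter. On that basis the step from compound 3 to compound 4 in this assay is expected to be small, about a number no higher from compound 3 to compound 4 (the limit leaves the size open). Compound 4 is therefore estimated to give roughly 100000 nM in this assay, with a range from 55000 nM to 250000 nM, and a good chance that only a limit is reported again.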

Compound 4, half-maximal inhibitory concentration: > 100000 nM
Compound 4: only a limit was reported; the forecaster's own chance of this, stated with the estimate: 60%; the middle value lies on the limit itself.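

In this assay compound 4 gives only a limit, > 100000 nM. Compound 3 also stands at a limit, so no step can be read from compound 3 to compound 4 for the change from 4-methylphenyl to 4-fluorophenyl. The compounds shown leave open how far this change moves the number on the core of compound 3, and what actual numbers compound 1, compound 3 and compound 4 would give: the limit of > 100000 nM in this assay, at which 3 of the 4 values shown sit.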